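Swapping tert-butyl for trifluoromethyl on an inactive compound

The source may hold more compounds than are shown below. What is called first, only, known or untested is meant among the compounds shown, and "the series" means these compounds.

For the measured compounds named here, in a functional assay on CWR22R cells (Homo sapiens) for antiproliferative activity, with a stated time of 96 h (a higher number here means a weaker inhibitor, a lower number a stronger inhibitor), compound 1 `Cc1cc(=O)oc2cc(OCC(=O)c3cc(C(F)(F)F)cc(C(F)(F)F)c3)ccc12` gives 930 nM, the only plain number so far. Compound 2 `Cc1cc(=O)oc2cc(OCC(=O)c3ccc(F)cc3)ccc12` sits at > 100000 nM, which is a limit of the assay and not a number. Compound 3 `CC(C)(C)c1ccc(C(=O)COc2ccc3c(C(F)(F)F)cc(=O)oc3c2)cc1` is reported only as "not active" (no number reported), so no single number fixes where it stands.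

Compound 4 `O=C(COc1ccc2c(C(F)(F)F)cc(=O)oc2c1)c1ccc(C(F)(F)F)cc1` has not yet been measured in this assay. The change trifluoromethyl in place of tert-butyl on an aromatic carbon puts trifluoromethyl in place of tert-butyl on an aromatic carbon, para to a large group. Going by the values given here, without a number for compound 3, the size of this step cannot be calculated, and no measured pair shows what this swap does on its own.

A step towards stronger inhibition is still expected, though a modest one, from no reported activity to a weak but measurable figure. Among the compounds with values here, the only support is compound 1, which also carries trifluoromethyl on an aromatic carbon and reaches 930 nM. That is thin evidence, so a result with no number remains quite possible. For compound 4 the estimated value is 15000 nM, with an expected range from 2000 nM to 100000 nM.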

Compound 4, half-maximal inhibitory concentration: "not active" (no number reported)
For compound 4 the study gives words and no number, and the estimate cannot be compared.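

Compound 3 and compound 4 are both reported in this assay only as "not active", with no number, so no step can be read between them. Left open is whether trifluoromethyl in place of tert-butyl changes activity at all, and how the words "not active" relate to the limit seen: the limit of > 100000 nM in this assay, at which 1 of the 4 values shown sits.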